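Ethoxy for methylamino on the shared core: cytotoxicity notes

The source may hold more compounds than are shown below. What is called first, only, known or untested is meant among the compounds shown, and "the series" means these compounds.

Measured so far:
compound 1 `O=c1ccc2nc(-c3ccccc3)nn(-c3ccccc3)c-2c1` — 810 nM
compound 2 `CNc1cc2nc(-c3ccccc3)nn(-c3ccccc3)c-2cc1=O` — 690 nM

In a functional assay on MCF7 cells (Homo sapiens) for cytotoxicity, read by MTT assay, with a stated time of 72 h (a higher number here means a weaker inhibitor, a lower number a stronger inhibitor), compound 1 gives 810 nM and compound 2 gives 690 nM. Compound 2 holds the lower of the two numbers, but the step of a 1.2-fold lower number from compound 1 to compound 2 (0.07 log units; within the scatter) lies within the scatter, so the two compounds cannot be ranked against each other. Compound 3 `CCOc1cc2nc(-c3ccccc3)nn(-c3ccccc3)c-2cc1=O` differs from compound 2 by ethoxy in place of methylamino on an aromatic carbon. Going by the values given here, no measured step exchanges a methylamino for an ethoxy; the only step known, a 1.2-fold lower number from compound 1 to compound 2 (0.07 log units; within the scatter), bears on it solely in showing that the methylamino itself moved the number from hydrogen by little. On this basis no step beyond the scatter is expected, and the step is estimated as a 1.1-fold higher number from compound 2 to compound 3 (0.04 log units; within the scatter). Compound 3 is therefore expected in this assay at about 750 nM, in a range from 300 nM to 2000 nM.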

Compound 3, half-maximal inhibitory concentration: > 5000 nM
Compound 3: no number, only a limit; the forecaster's own chance of this, stated with the estimate: 5%; middle value at least 6.6-fold (0.82 log units) away from the limit.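

In this assay compound 3 stands as a limit and not as a number: the limit of > 5000 nM in this assay, at which 1 of the 3 values shown sits. This position is therefore not indifferent to what it carries, since ethoxy in place of methylamino gives an at least 7.2-fold higher number from compound 2 to compound 3 (0.86 log units; beyond the scatter) and ethoxy in place of hydrogen gives an at least 6.1-fold higher number from compound 1 to compound 3 (0.79 log units; beyond the scatter) as the second step on the same position. Hydrogen and methylamino could not be ranked against each other, so the earlier pair gave no sign of a change of this size, and only ethoxy stands apart from both.

The compounds shown leave open whether the step follows the oxygen link or the longer chain, a question that methoxy and ethylamino on this carbon would separate. As far as these compounds go, how large the step really is also stays open, as only its lower bound can be read.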